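The source may report more compounds than this note shows. Statements on the series, on what has been measured and on what is new or still open speak of the compounds shown alone.

Compound 1 `CC(=O)/N=C1\NC2(CCCCO2)CCS1` gives 3.1 mg/kg in a functional assay on the whole organism (strain CF-1) with Mus musculus as the target, in the writhing test, with a stated time of 15 min; a lower number here means that less compound is needed, a higher number that more compound is needed for the effect.
Compound 2 `c1ccc(CNC2=NC3(CCCCO3)CCS2)cc1` reaches only the limit > 200 mg/kg in this assay.
Compound 3 `c1ccc(/N=C2\NC3(CCCCO3)CCS2)cc1` likewise reaches only the limit > 200 mg/kg in this assay.

For the measured compounds named here, compound 1 thus holds the only measured number in the set; the other two values sit at the limit of > 200 mg/kg in this assay, at which 2 of the 3 values shown sit. Compound 4 `O=C(/N=C1\NC2(CCCCO2)CCS1)c1cccs1` differs from compound 1 by thiophen-2-yl in place of methyl on a carbonyl carbon. Going by the values given here, the single measured step that alters the group on the double-bonded nitrogen, an at least 64-fold higher number from compound 1 to compound 3 (1.80 log units; beyond the scatter), is large and runs to the limit, but it removes the carbonyl that compound 4 keeps; no measured step varies the substituent on a carbonyl carbon. A moderate rise in this assay is therefore expected, a 4.8-fold higher number from compound 1 to compound 4 (0.68 log units; beyond the scatter), with a real chance of a limit. Compound 4 is estimated at 15 mg/kg, range 3 mg/kg to 100 mg/kg.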

Compound 4, dose for half-maximal effect: 48 mg/kg
Compound 4: the middle estimate sits 3.2-fold (0.51 log units) below what was measured; the measured number falls inside the stated range.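

On the carbonyl carbon, thiophen-2-yl in place of methyl gives in this assay a 15-fold higher number from compound 1 to compound 4 (1.19 log units; beyond the scatter) as a large step. This first measured step at this position shows that changing the substituent on the carbonyl carbon, with the carbonyl kept, moves the number beyond the scatter. Compound 4 still gives a measured number and does not sit at a limit: the limit of > 200 mg/kg in this assay, at which 2 of the 4 values shown sit.

On these data alone, with only methyl and thiophen-2-yl compared here, it stays open whether the rise follows the aromatic ring or simply the added atoms. Ethyl, cyclopropyl or phenyl on this carbonyl carbon would separate these readings.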